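The compounds below may be only part of what the source reports. "The series", "measured", "known", "first", "only" and "open" are said of these compounds alone.

Measured compounds:
- compound 1, `O=c1c(/C=C/c2coc3ccccc3c2=O)coc2ccccc12` — > 10000 nM
- compound 2, `O=c1c(Cc2coc3cccc(OCC4CCCCC4)c3c2=O)coc2cc(Cl)ccc12` — > 10000 nM
- compound 3, `COc1ccc2c(=O)c(Cc3coc4cccc(OCC5CCCCC5)c4c3=O)coc2c1` — 1200 nM

In a functional assay on MDA-MB-231 cells (Homo sapiens) for antiproliferative activity, read by XTT assay (on this read-out lower numbers stand for stronger inhibition and higher numbers for weaker inhibition), compound 1 gives only a limit, > 10000 nM. Compound 2 likewise returns a limit, > 10000 nM. Among the measured compounds shown here, compound 3 gives 1200 nM, the only number in the set; the two other values rest at the limit of > 10000 nM in this assay, at which 2 of the 3 values shown sit. For the measured compounds named here, compound 3 therefore stands alone as the one compound with a measured figure, and nothing can be said about its order against compounds 1 or 2 beyond the fact that they remain at the limit.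

Going by the values given here, the single measured step is an at least 8.3-fold lower number from compound 2 to compound 3 (0.92 log units; beyond the scatter). It shows that the substituent on the chromone bearing the methylene bridge matters, but it exchanges one group for another at that place and says nothing directly about removing a methyl from an oxygen.

Compound 4, `O=c1c(Cc2coc3cccc(OCC4CCCCC4)c3c2=O)coc2cc(O)ccc12`, differs from compound 3 by hydrogen in place of methyl on an oxygen on an aromatic ring. Among the compounds with values here, no measured step touches this oxygen, so the step to compound 4 has no direct precedent; the step from compound 2 to compound 3 only indicates that this position is sensitive. In this assay the change is expected to stay close to compound 3, with a 1.3-fold higher number from compound 3 to compound 4 (0.10 log units; within the scatter) as the estimated step. Compound 4 is thus estimated at 1500 nM, in the range 500 nM to 6000 nM.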

Compound 4, half-maximal inhibitory concentration: 3220 nM
The estimate for compound 4 lay 2.1-fold (0.33 log units) below the measured number; measured number inside the range.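

In this assay, the oxygen on the aromatic ring now has a direct reading: hydrogen in place of methyl gives a 2.7-fold higher number from compound 3 to compound 4 (0.43 log units; beyond the scatter). The change from methoxy to hydroxy therefore weakens the read-out but still leaves a measured number, and methoxy holds the lower number of the two. Hydroxy in place of chloro on the aromatic carbon gives an at least 3.1-fold lower number from compound 2 to compound 4 (0.49 log units; beyond the scatter), so compounds 3 and 4 both read lower than compound 2, whichever group sits on the oxygen. Compound 2 is only a limit, which leaves these comparisons with chloro without an exact size: the limit of > 10000 nM in this assay, at which 2 of the 4 values shown sit.

The compounds shown leave open how an amine, an ethoxy group or a longer alkoxy chain would read at this place, and so whether methoxy is the best of such groups or only the better of two. From the compounds shown here alone, compounds 2, 3 and 4 also share the same ether bearing the cyclohexane ring, and whether the order of methoxy, hydroxy and chloro holds with a shorter chain or a carboxylic acid in its place remains open.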